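Ester chain enlargement on the dihydropyridine series

This account rests on a few compounds, and the source may have more. Where it says the series, first, only, none or still open, it means among the compounds named here.

Compound 2 `CCOC(=O)C1=C(C)NC(C)=C(C(=O)OC(C)C)C1c1cnc(SC)n1Nc1ccccc1` in an assay on isolated protein (strain albino) for antagonist activity at Voltage-dependent L-type calcium channel subunit alpha-1C (Cavia porcellus) (a lower number here means a stronger inhibitor, a higher number a weaker inhibitor), gives 3.22 nM. Of the three measured values it carries the largest number, but compound 3 `CCOC(=O)C1=C(C)NC(C)=C(C(=O)OCCCc2ccccc2)C1c1cnc(SC)n1Nc1ccccc1` at 2.54 nM and compound 1 `CSc1ncc(C2C(C(=O)OC(C)C)=C(C)NC(C)=C2C(=O)OC(C)C)n1Nc1ccccc1` at 2.16 nM both lie within the scatter of it: a 1.5-fold higher number from compound 1 to compound 2 (0.17 log units; within the scatter) and a 1.3-fold lower number from compound 2 to compound 3 (0.10 log units; within the scatter). All three ester variants therefore sit in one narrow band.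

Compound 4 `CSc1ncc(C2C(C(=O)OCc3ccccc3)=C(C)NC(C)=C2C(=O)OC(C)C)n1Nc1ccccc1` differs from compound 2 by phenyl in place of methyl on a saturated chain carbon bound to an oxygen next to a carbonyl group. Within the data shown here, two measured steps bear on this: the step from compound 1 to compound 2 alters the same ester chain by a single carbon, and the step from compound 2 to compound 3 places a phenyl-bearing chain on the other ester oxygen; neither moved this assay beyond its scatter. Among the measured compounds shown here, nothing among the measured compounds shows that adding a phenyl at this chain position changes the number, so no step beyond the scatter is expected here either.

Compound 4 is thus expected to land close to compound 2, with an estimated 1.2-fold lower number from compound 2 to compound 4 (0.06 log units; within the scatter) reflecting a flat response. The estimate for compound 4 is 2.8 nM, ranging from 1.3 nM to 6 nM.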

Compound 4, half-maximal inhibitory concentration: 7.24 nM
Compound 4: the middle estimate sits 2.6-fold (0.41 log units) below what was measured; measured number outside the range, above it.
By their numbers in this assay, from the lowest: compounds 1, 3 and 2 (each within the scatter of the next); then compound 4.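

Ethoxycarbonyl to benzyloxycarbonyl is the first change on this ester chain to leave the scatter in this assay, where the step reads (a 2.2-fold higher number from compound 2 to compound 4 (0.35 log units; beyond the scatter)), and the comparison with the isopropyl ester points the same way (a 3.4-fold higher number from compound 1 to compound 4 (0.53 log units; beyond the scatter)), so this position is not as flat as the earlier steps suggested. The phenyl-bearing chain of compound 3 stayed within the scatter (a 1.3-fold lower number from compound 2 to compound 3 (0.10 log units; within the scatter)), so a phenyl on an ester chain does not in itself go with a higher number in this short series, although compound 3 and compound 4 differ in both chain and ester position, and the two changes cannot be separated. The shift remains modest, and nothing available accounts for it.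

Open, from the compounds shown here alone, is whether the higher number belongs to the benzyl group specifically or to any ring-bearing chain on this oxygen, which a 2-phenylethyl or 3-phenylpropyl ester here, set against cyclohexylmethyl, would help to settle. Also open, going by these compounds, is whether a benzyl ester on the other oxygen, with ethyl kept in place, would give the same step.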